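Methoxy for chloro on a shared benzo-fused core

This account rests on a few compounds, and the source may have more. Where it says the series, first, only, none or still open, it means among the compounds named here.

Of the compounds shown here, two have been measured in an assay on isolated protein for inhibition of thyroid hormone receptor beta (Homo sapiens), read by fluorescence, with a stated time of 30 min; a higher number here means a weaker inhibitor, a lower number a stronger inhibitor. Compound 1 `O=C(NCc1cccc(Cl)c1)c1cc(Cl)c2cn(CCn3cccn3)nc2c1` gives 225 nM. Compound 2 `CCCN(CC1CCOC1)C(=O)c1cc(Cl)c2oc(NCc3cccc(Cl)c3)nc2c1` gives 71 nM, the lowest of the two numbers, and its step from compound 1 is beyond the scatter. Compound 3 `CCCN(CC1CCOC1)C(=O)c1cc(OC)c2oc(NCc3cccc(Cl)c3)nc2c1` differs from compound 2 in one place: methoxy in place of chloro on an aromatic carbon, on an aromatic carbon of a six-membered carbon-only ring within a fused system of two rings, ortho to a fused ring, meta to a fused ring and meta to a large group. Going by the values given here, no pair that separates this exact change has been measured, so the size of the step rests only on expectation; he expects a step from compound 2 to compound 3 of a 2.1-fold higher number from compound 2 to compound 3 (0.32 log units; beyond the scatter), toward a somewhat higher number, likely near the edge of the scatter rather than far beyond it. For compound 3 he therefore expects 150 nM, with a range from 50 nM to 450 nM.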

Compound 3, half-maximal inhibitory concentration: 12 nM
Compound 3: middle estimate off by 13-fold (1.10 log units), on the high side; measured number below the stated range.
By their numbers in this assay, from the lowest: compound 3; then compound 2; then compound 1.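

Methoxy in place of chloro on this aromatic carbon gives, in this assay, a 5.9-fold lower number from compound 2 to compound 3 (0.77 log units; beyond the scatter), which shows that this position responds to what stands on it; compound 1 and compound 2 differ in more than one place and could not show this. The position takes a group of two heavy atoms with a hydrogen-bond acceptor in place of one heavy atom without one, and the number still falls. The compounds shown offer no measurement that accounts for this fall.

From the compounds shown here alone, whether the oxygen or the methyl of the methoxy matters stays open, as does how a hydroxy, an ethoxy or an amine would fare here. Going by these compounds, it is also open whether the same change would give a similar step on the core of compound 1.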